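The source may report more compounds than this note shows. Statements on the series, on what has been measured and on what is new or still open speak of the compounds shown alone.

The series shares one core, seen in compound 1 `CC(C(=O)NCc1ccc(C(F)(F)F)cc1N1CCC(C(F)(F)F)CC1)c1ccc(NS(C)(=O)=O)c(F)c1` and compound 2 `CC(C(=O)NCc1ccc(C(F)(F)F)cc1N1CCC(c2ccc(F)cc2)CC1)c1ccc(NS(C)(=O)=O)c(F)c1`. In an assay on CHO cells for antagonist activity at transient receptor potential cation channel subfamily V member 1 (Homo sapiens), read by FLIPR (on this read-out lower numbers stand for stronger inhibition and higher numbers for weaker inhibition), compound 1 gives 0.4 nM, and compound 2 gives 0.9 nM. Among these two numbers compound 2 stands with the higher figure, which on this read-out means the weaker inhibition; the only measured step, a 2.3-fold higher number from compound 1 to compound 2 (0.35 log units; beyond the scatter), separates the two. Compound 3 `CC(C(=O)NCc1ccc(C(F)(F)F)cc1N1CCC(Cc2ccc(F)cc2)CC1)c1ccc(NS(C)(=O)=O)c(F)c1` is not yet measured. It differs from compound 2 in a single place: 4-fluorobenzyl in place of 4-fluorophenyl on a saturated ring carbon. Among the measured compounds shown here, no measured step matches this change directly; the sole measured step, a 2.3-fold higher number from compound 1 to compound 2 (0.35 log units; beyond the scatter), exchanges the whole group on that saturated ring carbon rather than extending it, so it serves only as a loose guide that a change at this carbon has so far shifted the number modestly. The expectation for compound 3 in this assay is therefore a step of a 1.7-fold higher number from compound 2 to compound 3 (0.22 log units; within the scatter), small and possibly not beyond the scatter. Compound 3 is estimated at 1.5 nM, with a range from 0.5 nM to 5 nM.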

Compound 3, inhibition constant: 0.4 nM
Compound 3: the middle estimate sits 3.8-fold (0.57 log units) above what was measured; measured number outside the range, below it.
By their numbers in this assay, from the lowest: compounds 1 and 3 (each within the scatter of the next); then compound 2.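

In this assay the change from 4-fluorophenyl to 4-fluorobenzyl on this saturated ring carbon gives a 2.3-fold lower number from compound 2 to compound 3 (0.35 log units; beyond the scatter) and so shows that the number here responds to how the aromatic ring is attached, not only to whether one is present. Trifluoromethyl and 4-fluorobenzyl on the same carbon cannot be told apart in this assay (no change at the digits printed from compound 1 to compound 3 (within the scatter)), so a group with an aromatic ring can match one without, and of these three compounds only compound 2 stands apart. Nothing in the data shown explains why 4-fluorobenzyl gives a lower number than 4-fluorophenyl.

Open, as far as these compounds go, is how far this tolerance extends, since every group compared so far carries no hydrogen-bond donor or acceptor and no net charge. A longer chain ending in the same 4-fluorophenyl ring, or an amine or a carboxylic acid on this carbon, would show whether the number stays this low or whether the position has a limit.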